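Iodo compound 3 to its methyl counterpart, compound 4

This account rests on a few compounds, and the source may have more. Where it says the series, first, only, none or still open, it means among the compounds named here.

Measured in a functional assay on HeLa S3 cells (Homo sapiens) for antiproliferative activity, read by XTT assay, with a stated time of 72 h; a lower number here means a stronger inhibitor, a higher number a weaker inhibitor:
- compound 1 `Cc1ncnc2c1c(-c1ccsc1)cn2[C@@H]1O[C@H](CO)[C@@H](O)[C@H]1O`: 14300 nM
- compound 2 `C#Cc1cn([C@@H]2O[C@H](CO)[C@@H](O)[C@H]2O)c2ncnc(C)c12`: 14700 nM
- compound 3 `CNc1ncnc2c1c(I)cn2[C@@H]1O[C@H](CO)[C@@H](O)[C@H]1O`: > 20000 nM

For compound 3 the entry > 20000 nM is a limit and not a number. It is the only such entry, as the limit of > 20000 nM in this assay, at which 1 of the 3 values shown sits, records.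

The next structure, compound 4 `Cc1ncnc2c1c(I)cn2[C@@H]1O[C@H](CO)[C@@H](O)[C@H]1O`, has methyl in place of methylamino on an aromatic carbon.

For the measured compounds named here, no measured step covers this exchange directly. Going by the values given here, the one step available is a 1.0-fold higher number from compound 1 to compound 2 (0.01 log units; within the scatter), and it leaves the readings of the two compounds within the scatter of each other. Both of those compounds carry the methyl that enters in compound 4. In this assay compound 1 gives 14300 nM and compound 2 gives 14700 nM. Among the compounds with values here, these two values are the only numbers to anchor an expectation, so compound 4 is expected to fall in the same region. That would mean a modest move to a lower number, though a reading at the limit again remains possible.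

The expected step, which rests on a limit and is therefore approximate, is an at least 1.6-fold lower number from compound 3 to compound 4 (0.22 log units; that floor lies within the scatter).

For compound 4 the estimated value is 12000 nM, with an expected range of 3500 nM to 20000 nM.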

Compound 4, half-maximal inhibitory concentration: 4080 nM
For compound 4 the middle estimate is 2.9-fold (0.47 log units) above the measured one, and the stated range covers the measured number.
By their numbers in this assay, from the lowest: compound 4; then compounds 1 and 2 (each within the scatter of the next). At a limit, above all of these: compound 3.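

In this assay, for the compounds shown here, methyl in place of methylamino on this aromatic carbon gives an at least 4.9-fold lower number from compound 3 to compound 4 (0.69 log units; beyond the scatter) and so marks the first exchange here that clears the scatter, though the size of that step can be read only as a floor. With this methyl held constant, the group on the other substituted aromatic carbon also proves able to shift the reading: iodo in place of ethynyl gives a 3.6-fold lower number from compound 2 to compound 4 (0.56 log units; beyond the scatter) and iodo in place of thiophen-3-yl gives a 3.5-fold lower number from compound 1 to compound 4 (0.54 log units; beyond the scatter), whereas ethynyl in place of thiophen-3-yl gave a 1.0-fold higher number from compound 1 to compound 2 (0.01 log units; within the scatter) and did not separate those two groups. The reading for compound 3 is a limit and not a number: the limit of > 20000 nM in this assay, at which 1 of the 4 values shown sits.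

Still open, from the compounds shown here alone, is how far the methyl itself is preferred at this position, as only methylamino stands against it, so an ethyl, a methoxy or a primary amine on the same carbon would show whether the trend holds beyond this one pair. On the other carbon, bromo or chloro in place of iodo would show whether the lower reading of compound 4 is particular to iodo or extends to the smaller halogens.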